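Dropping the ring: propylamino in place of methylcyclohexylamino

This account rests on a few compounds, and the source may have more. Where it says the series, first, only, none or still open, it means among the compounds named here.

The three measured compounds share one core, a salicylanilide carrying chlorine, and differ only in the group on the far aniline nitrogen. Compound 1 `CCCN(CCC)c1ccc(NC(=O)c2cc(Cl)ccc2O)c(Cl)c1` carries a dipropylamino group there and in an ADME assay on A549 cells (Homo sapiens) for cytotoxicity, read by LDH release, with a stated time of 15 h (a higher number here means that more compound is tolerated, a lower number that less compound is tolerated), compound 1 gives 323000 nM. Compound 2 `CC1(Nc2ccc(NC(=O)c3cc(Cl)ccc3O)c(Cl)c2)CCCCC1` carries a (1-methylcyclohexyl)amino group instead, and in this assay compound 2 gives 86500 nM, the lowest of the two numbers reported; the step is a 3.7-fold lower number from compound 1 to compound 2 (0.57 log units; beyond the scatter). Compound 3 `O=C(Nc1ccc(NCCCO)cc1Cl)c1cc(Cl)ccc1O` carries a hydroxypropylamino group; in this assay the entry for compound 3 reads "not determined" (no result reported), so no number is available for it.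

Compound 4 `CCCNc1ccc(NC(=O)c2cc(Cl)ccc2O)c(Cl)c1` is reached from compound 2 by the change (propyl in place of 1-methylcyclohexyl on a nitrogen on an aromatic ring). For the measured compounds named here, only one measured step bears on this, the one from compound 1 to compound 2, where replacing dipropylamino by (1-methylcyclohexyl)amino gave a modest change beyond the scatter. Compound 4 keeps a single propyl chain, smaller than either of those groups, so a move back toward the number of compound 1 is expected, though probably not all of the way, since the step of a 2.3-fold higher number from compound 2 to compound 4 (0.36 log units; beyond the scatter) is estimated from a single comparison. Compound 4 is therefore expected to give about 200000 nM in this assay, with a range from 80000 nM to 500000 nM.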

Compound 4, half-maximal cytotoxic concentration: 69700 nM
Beside the measured number, compound 4's estimate is 2.9-fold (0.46 log units) above it; the measured number lies below the stated range.
By their numbers in this assay, from the lowest: compounds 4 and 2 (each within the scatter of the next); then compound 1.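

In this assay, putting propyl in place of 1-methylcyclohexyl on the nitrogen exchanges a six-membered carbon ring for an open chain of fewer heavy atoms, yet the result is a 1.2-fold lower number from compound 2 to compound 4 (0.09 log units; within the scatter) and so these two groups cannot be told apart here. The clearer difference is a 4.6-fold lower number from compound 1 to compound 4 (0.67 log units; beyond the scatter) with hydrogen in place of propyl on the nitrogen, and together with the earlier step this places the two compounds that keep a hydrogen on this nitrogen, compound 2 and compound 4, on the lower side of compound 1, which carries two propyl chains there. No measurement at hand gives a reason for either step.

On these data alone, it remains open whether another nitrogen with two chains, such as dimethylamino, would fall with compound 1, and whether a bare amine or a longer chain such as hexylamino would fall with compound 2 and compound 4. The hydroxypropylamino group of compound 3 also stays unplaced, since that entry carries no number, so the effect of a hydroxyl at the end of the chain cannot be read.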